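The source may hold more compounds than are shown below. What is called first, only, known or untested is meant among the compounds shown, and "the series" means these compounds.

Working notes on the series. In a functional assay with muscarinic acetylcholine receptor M3 (Cavia porcellus) as the target (on this read-out lower numbers stand for smaller maximal responses and higher numbers for larger maximal responses), compound 1 `C[C@H]1O[C@@H](C[N+](C)(C)C)CC1(F)F` gives 0.95 and compound 2 `C[C@@H]1O[C@H](C[N+](C)(C)C)CC1(F)F` gives 0.83, the lower of the two numbers. The step a number 0.12 lower from compound 1 to compound 2 (beyond the scatter) rests on (the fact that compounds 1 and 2 differ only in the configuration as drawn). Compound 3 `C[C@@H]1O[C@@H](C[N+](C)(C)C)CC1(F)F` is not yet measured; it differs from compound 2 in that (the two compounds have the same atoms and bonds and differ only in configuration as drawn: 1 of 2 stereo elements differ; a stereocentre at a saturated ring carbon is drawn S in compound 2 and R in compound 3). For the measured compounds named here, the single measured step bears on a change of both centres, not of one, so it gives only a weak guide, and the expected change a number 0.030 lower from compound 2 to compound 3 (within the scatter) is modest in either direction. Compound 3 is therefore estimated at 0.8, within 0.5 to 1.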

Compound 3, intrinsic activity: the largest response reached, as a fraction of the reference agonist's: 1
Estimate against measurement, compound 3: 0.20 below; the range from low to high includes it.
By their numbers in this assay, from the lowest: compound 2; then compounds 1 and 3 (each within the scatter of the next).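

Inverting a single stereocentre is enough to move the number beyond the scatter: a number 0.17 higher from compound 2 to compound 3 (beyond the scatter). Inverting the other stereocentre does not, as a number 0.050 higher from compound 1 to compound 3 (within the scatter) shows, so the two centres do not count alike within this set of compounds. The larger step rests on configuration alone: the fact that compounds 2 and 3 differ only in the configuration as drawn.

On these data alone, the fourth arrangement of the two stereocentres remains open, so it is unknown whether this difference between the centres holds across all arrangements. Also open, as far as these compounds go, is how a tertiary amine, or an ethyl group in place of the methyl, would read on the same core.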